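From compound 3 to compound 4: a ring exchange

The source may hold more compounds than are shown below. What is called first, only, known or untested is meant among the compounds shown, and "the series" means these compounds.

In a physicochemical assay for acid dissociation, compound 1 (`COc1ccc(CN(CCN(C)C)c2ccccc2)cc1`) gives 9.7 and compound 2 (`COc1ccc(CN(CCN(C)C)c2ccc(Cl)cc2)cc1`) gives 9.6 in the same series. Compound 3 (`COc1ccc(CN(CCN(C)C)c2ccc(C)cc2)cc1`) gives 9.8 and lies within the scatter of both.

Compound 4 (`COc1ccc(CN(CCN(C)C)c2ccc(Cl)cn2)cc1`) carries 5-chloropyridin-2-yl in place of 4-methylphenyl on an amine nitrogen. The nearest measured evidence is the exchange of methyl and chloro, seen as a number 0.20 log units higher from compound 2 to compound 3 (within the scatter) on an aromatic carbon. Chloro in place of hydrogen gives a number 0.10 log units lower from compound 1 to compound 2 (within the scatter) and methyl in place of hydrogen gives a number 0.10 log units higher from compound 1 to compound 3 (within the scatter) in the same read-out. All three steps are small, and read in reverse the first one points slightly downward for the chloro part of the change.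

Within the data shown here, none of the measured compounds has a six-membered aromatic ring with 1 hetero atom, so that part has no measured step to lean on. The judgement here is a moderate fall, with a wide margin for the unmeasured ring. The expected change is a number 0.60 log units lower from compound 3 to compound 4 (beyond the scatter) in this estimate. For compound 4 the estimated value is 9.2 with an expected range of 8.7 to 9.7 in this assay once measured.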

Compound 4, acid dissociation constant: 9.5
Estimate against measurement, compound 4: 0.30 log units below, and the stated range covers the measured number.
By their numbers in this assay, from the lowest: compounds 4, 2, 1 and 3 (each within the scatter of the next).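

In this assay the exchange of a carbon-only aromatic ring for a six-membered aromatic ring with 1 hetero atom, on an amine nitrogen, now has measured steps, and all three lie within the scatter: (a number 0.30 log units lower from compound 3 to compound 4 (within the scatter)), (a number 0.10 log units lower from compound 2 to compound 4 (within the scatter)) and (a number 0.20 log units lower from compound 1 to compound 4 (within the scatter)). At this position 5-chloropyridin-2-yl is therefore not told apart from 4-methylphenyl, 4-chlorophenyl or phenyl, so even a group that brings a hydrogen-bond acceptor leaves compounds 1 to 4 without a single step beyond the scatter. Nothing available accounts for this outcome.

The compounds shown leave open whether the ring nitrogen and the chloro contribute separately here, since unsubstituted pyridin-2-yl does not appear among them, and whether a ring with a second ring nitrogen, such as pyrimidin-2-yl, would also stay within the scatter. Among these compounds, they also leave open whether a stronger change on the ring, such as a nitrile or a carboxylic acid in place of the chloro, would produce the first step beyond the scatter.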